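The compounds below may be only part of what the source reports. "The series", "measured", "known", "first", "only" and "open" are said of these compounds alone.

Measured so far:
compound 1, `Nc1nc(Cl)c2ncn(Cc3ccccc3CCl)c2n1`, 26900 nM
compound 2, `Nc1nc(Cl)c2ncn(Cc3cccc(CCl)c3)c2n1`, 22400 nM

Both compounds were tested in a functional assay on MDA-MB-435 cells (Homo sapiens) for cytotoxicity, read by sulforhodamine B assay, with a stated time of 48 h; on this read-out higher numbers stand for weaker inhibition of growth and lower numbers for stronger inhibition of growth. Compound 1 has the highest of the two numbers, and compound 2 sits a little lower, but the gap between them falls within the usual scatter of repeated measurements, so the two cannot be told apart on these data.

Compound 3, `ClCc1ccccc1Cn1cnc2c(Cl)ncnc21`, has not yet been measured. It differs from compound 1 in one place: hydrogen in place of amino on an aromatic carbon. Everything else in the shared core and its side chain stays as it is.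

Among the measured compounds shown here, no measured pair in this set shows what removing an amino group from this position does, so the size of the step in this assay cannot be read off from existing numbers. The expectation is a step of modest size, or none beyond the scatter, with no clear direction. The expected step of a 1.1-fold higher number from compound 1 to compound 3 (0.05 log units; within the scatter) reflects that. For compound 3 the estimated value is 30000 nM, with a likely range from 8000 nM to 100000 nM.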

Compound 3, concentration for total growth inhibition: 9550 nM
For compound 3 the middle estimate is 3.1-fold (0.50 log units) above the measured one; measured number inside the range.
By their numbers in this assay, from the lowest: compound 3; then compounds 2 and 1 (each within the scatter of the next).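

Putting hydrogen in place of amino on this aromatic carbon, between two ring nitrogen atoms, gives a 2.8-fold lower number from compound 1 to compound 3 (0.45 log units; beyond the scatter) in this assay and so means stronger inhibition of growth. The amino group at this position is therefore not needed for the effect on these cells, and the result depends on what sits there, at least for this pair. The data shown offer no explanation for why this change has this effect.

This single step does not show whether the same change would act alike with the chloromethyl group in its place on compound 2. It also leaves open how a methyl group, a hydroxyl group or a methylamino group on the same carbon would compare with hydrogen and amino.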